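Swapping a Ring on the Sulfonyl Group: Cytotoxicity Expected

The compounds below may be only part of what the source reports. "The series", "measured", "known", "first", "only" and "open" are said of these compounds alone.

Measured compounds:
- compound 1 `O=C(Nc1ccc(F)c(Cl)c1)c1ccc(F)c(S(=O)(=O)N2CCCCCC(O)C2)c1`: 11000 nM
- compound 2 `O=C(Nc1ccc(F)c(Cl)c1)c1ccc(F)c(S(=O)(=O)N2CCOC[C@H](O)C2)c1`: 19000 nM
- compound 3 `O=C(Nc1ccc(F)c(Cl)c1)c1ccc(F)c(S(=O)(=O)N2CCCCCCC2O)c1`: 7000 nM

All three were tested in an ADME assay on HepG2 2.2.15 cells (Homo sapiens) for cytotoxicity, read by luminescence, with a stated time of 3 days; on this read-out higher numbers stand for lower toxicity in this test and lower numbers for higher toxicity in this test. Compound 3 gives the lowest of the three numbers, though its gap to compound 1 is within the scatter, as the step of a 1.6-fold lower number from compound 1 to compound 3 (0.20 log units; within the scatter) shows; only its gap to compound 2, the step of a 2.7-fold lower number from compound 2 to compound 3 (0.43 log units; beyond the scatter), lies beyond it.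

Compound 4 `O=C(Nc1ccc(F)c(Cl)c1)c1ccc(F)c(S(=O)(=O)N2CCOC[C@@H](O)C2)c1` differs from compound 3 in one place: a group of 8 heavy atoms (5 carbon, 1 nitrogen, 2 oxygen; one seven-membered non-aromatic ring with 2 hetero atoms) in place of a group of 9 heavy atoms (7 carbon, 1 nitrogen, 1 oxygen; one eight-membered non-aromatic ring with 1 hetero atom), on a sulfonyl sulfur. Compound 4 thus carries the same 6-hydroxy-1,4-oxazepan-4-yl group as compound 2, differing from compound 2 only in the arrangement at its one defined stereocentre. The step that bears directly on this change is a 2.7-fold lower number from compound 2 to compound 3 (0.43 log units; beyond the scatter), the same swap run the other way, which was modest but beyond the scatter. The step of a 1.7-fold higher number from compound 1 to compound 2 (0.24 log units; within the scatter) also points the same way, though within the scatter.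

Compound 4 is therefore expected to show a rise in this assay of about a 2.4-fold higher number from compound 3 to compound 4 (0.39 log units; beyond the scatter). The estimate for compound 4 is 17000 nM, with a range from 8000 nM to 35000 nM.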

Compound 4, half-maximal cytotoxic concentration: 14000 nM
For compound 4 the middle estimate is 1.2-fold (0.08 log units) above the measured one; the measured number falls inside the stated range.
By their numbers in this assay, from the lowest: compounds 3, 1, 4 and 2 (each within the scatter of the next, the first and the last beyond it).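

In this assay, inverting the one defined stereocentre of the 6-hydroxy-1,4-oxazepan-4-yl group gives a 1.4-fold lower number from compound 2 to compound 4 (0.13 log units; within the scatter), so this test does not separate the two arrangements, and this pair isolates that single feature: the fact that compounds 2 and 4 differ only in the configuration as drawn

Set against the eight-membered rings, the new arrangement gives a 2.0-fold higher number from compound 3 to compound 4 (0.30 log units; within the scatter) and a 1.3-fold higher number from compound 1 to compound 4 (0.10 log units; within the scatter), so neither step can be read as a real change. Within the data shown here, the only step beyond the scatter in this set therefore remains a 2.7-fold lower number from compound 2 to compound 3 (0.43 log units; beyond the scatter), which rests on one arrangement of the ring and a small margin.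

Every ring shown carries a hydroxyl, so it remains open how the read-out would respond to an amine or a carboxylic acid in its place. Going by these compounds, whether a morpholine ring on the sulfonyl sulfur would fall within this same narrow band also remains open.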